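The source may hold more compounds than are shown below. What is called first, only, known or untested is meant among the compounds shown, and "the series" means these compounds.

Two compounds of the series have been run in a toxicity assay on THP-1 cells (Homo sapiens) for inhibition; a higher number here means that more compound is tolerated, a lower number that less compound is tolerated. Compound 1 `Cn1c(-c2cccc([N+](=O)[O-])c2)cnc1NC(=O)c1ccc(F)cc1` sits at the assay limit (the limit of > 50000 nM in this assay, at which 1 of the 2 values shown sits); in this assay compound 1 gives > 50000 nM, which is a limit and not a number. Compound 2 `COc1ccc(C(=O)Nc2ncc(-c3ccc(OC)cc3)n2C)cc1` sits at the assay limit (the limit of > 100000 nM in this assay, at which 1 of the 2 values shown sits); in this assay compound 2 gives > 100000 nM, again a limit and not a number. Going by the values given here, with both values shown as limits, no measured step between them can be stated, and compound 2 stands simply at the higher of the two limits reached.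

Compound 3 `COc1ccc(-c2cnc(NC(=O)c3cccc(C)c3)n2C)cc1` differs from compound 2 by 3-methylphenyl in place of 4-methoxyphenyl on a carbonyl carbon. Among the compounds with values here, no measured step covers a change of this kind. Compound 3 is expected to stay at the tolerated end of this assay, with the step estimated as a step that the limit leaves unreadable from compound 2 to compound 3, none beyond the scatter. The estimate for compound 3 in this assay is 150000 nM, within 60000 nM to 400000 nM, and most likely reported only as a limit.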

Compound 3, half-maximal cytotoxic concentration: > 100000 nM
Compound 3: only a limit was reported; the forecaster's own chance of this, stated with the estimate: 80%; the middle value is on the limit's open side.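

Compound 2 and compound 3 both stand as limits and not numbers in this assay, so no step between them can be read: the limit of > 100000 nM in this assay, at which 2 of the 3 values shown sit.

The compounds shown leave open what number any of the three would give in this assay, and whether 3-methylphenyl in place of 4-methoxyphenyl changes it.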